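Chain extension on the methylamino of compound 1

The source may report more compounds than this note shows. Statements on the series, on what has been measured and on what is new or still open speak of the compounds shown alone.

Measured compounds:
- compound 1 `CNc1nc(N)c2nc(O)n(Cc3ccccc3)c2n1`: 1 uM
- compound 2 `COc1nc(N)c2nc(O)n(Cc3ccccc3)c2n1`: 0.1 uM

The series is read in a functional assay (spleen, spleen) for activation, with Mus musculus as the target; on this read-out lower numbers stand for an effect already at smaller amounts and higher numbers for an effect only at larger amounts of compound. Compound 1 gives 1 uM and compound 2 gives 0.1 uM. Within the data shown here, compound 1 thus has the highest of the two numbers; its nearest neighbour is compound 2, and the only step measured so far is a 10-fold lower number from compound 1 to compound 2 (1.00 log units; beyond the scatter).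

Compound 3 `CCCNc1nc(N)c2nc(O)n(Cc3ccccc3)c2n1` is the next compound to be measured in this assay. It differs from compound 1 in one place: ethyl in place of hydrogen on a saturated chain carbon bound to a nitrogen on an aromatic ring. Among the measured compounds shown here, the one measured step, from compound 1 to compound 2, swaps the methylamino for a methoxy and so does not test a longer chain on the same nitrogen; it has no direct bearing on the change to compound 3. With no step of this kind in hand, no shift beyond the usual scatter is expected, though a move in either direction cannot be excluded.

Compound 3 is therefore expected to give about 1 uM, within 0.3 uM to 3 uM, which would mean an estimated step of no change at the digits printed from compound 1 to compound 3 (within the scatter).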

Compound 3, minimum effective concentration: 0.1 uM
The estimate for compound 3 lay 10-fold (1.00 log units) above the measured number; measured number outside the range, below it.
By their numbers in this assay, from the lowest: compounds 2 and 3 (each within the scatter of the next); then compound 1.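

In this assay, extending methylamino to propylamino gives a 10-fold lower number from compound 1 to compound 3 (1.00 log units; beyond the scatter) and so shows that this chain position responds to added carbon, which the swap to methoxy could not test. The comparison of the two replacements gives no change at the digits printed from compound 2 to compound 3 (within the scatter) and places propylamino and methoxy level on this read-out, although one change keeps the nitrogen and the other replaces it with oxygen, so among these three compounds methylamino alone stands apart. No measurement in hand accounts for either step, and nothing available explains why the ethyl extension shifts the number on this result.

The compounds shown do not say whether ethylamino already carries the full shift, or whether butylamino or pentylamino would move the number further or reverse it. From the compounds shown here alone, whether branched chains such as isopropylamino, or a longer ether such as propoxy in place of methoxy, would follow the same course also remains open.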